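This account rests on a few compounds, and the source may have more. Where it says the series, first, only, none or still open, it means among the compounds named here.

Among the measured compounds shown here, compound 2 `COc1cccc(-n2cc(CN3C(=O)C[C@@H]4CC[C@@]3(C)C4(C)C)nn2)c1` gives 590 nM in a functional assay on SGC-7901 cells (Homo sapiens) for inhibition, read by MTT assay, with a stated time of 24 h; on this read-out lower numbers stand for stronger inhibition and higher numbers for weaker inhibition; this is the higher of the two numbers measured so far, the nearest being compound 1 `CC1(C)[C@H]2CC[C@]1(C)N(Cc1cn(-c3cccc(O)c3)nn1)C(=O)C2` with 270 nM, one step away: a 2.2-fold higher number from compound 1 to compound 2 (0.34 log units; beyond the scatter). Compound 3 `CC1(C)[C@H]2CC[C@]1(C)N(Cc1cn(-c3ccccc3F)nn1)C(=O)C2` differs from compound 2 by 2-fluorophenyl in place of 3-methoxyphenyl on an aromatic nitrogen. For the measured compounds named here, the single measured step concerns only the group on that oxygen and leaves the aryl ring itself untouched, so no measured step bears directly on this change, and no step in this assay beyond the scatter is expected in either direction. Compound 3 is therefore estimated at 500 nM, range 200 nM to 1500 nM, an expected step of a 1.2-fold lower number from compound 2 to compound 3 (0.07 log units; within the scatter).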

Compound 3, half-maximal inhibitory concentration: 300 nM
For compound 3 the middle estimate is 1.7-fold (0.22 log units) above the measured one; low and high end bracket the measured number.
By their numbers in this assay, from the lowest: compounds 1, 3 and 2 (each within the scatter of the next, the first and the last beyond it).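

In this assay, replacing the oxygen-bearing aryl group on the aromatic nitrogen with 2-fluorophenyl gives a 2.0-fold lower number from compound 2 to compound 3 (0.29 log units; within the scatter) and a 1.1-fold higher number from compound 1 to compound 3 (0.05 log units; within the scatter), so neither step leaves the scatter. An oxygen on this aryl ring is therefore not required to stay in this range, since compound 3 carries only fluorine there. No evidence accompanies these numbers to account for them.

Still open, as far as these compounds go, is how an amine or a carboxylic acid on this phenyl ring would read, and whether 3-fluorophenyl would match 2-fluorophenyl.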